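This account rests on a few compounds, and the source may have more. Where it says the series, first, only, none or still open, it means among the compounds named here.

Measured compounds, all in a functional assay on 786-0 cells (Homo sapiens) for cytotoxicity, read by sulforhodamine B assay, with a stated time of 48 h, tested at 10 uM; a higher number here means a weaker effect of the compound at the concentration tested, a lower number a stronger effect:

compound 1 `COc1ccc(-c2cc(/C=C/C(=O)c3ccc(N)cc3)[nH]n2)cc1` gives -29%
compound 2 `COc1ccc(C(=O)/C=C/c2cc(-c3cc(OC)c(OC)c(OC)c3)n[nH]2)cc1OC` gives -88%
compound 3 `COc1ccc(-c2cc(/C=C/C(=O)c3ccc(N)cc3)[nH]n2)cc1OC` gives -48%

Compound 1 and compound 3 share a core and differ in one place, (methoxy in place of hydrogen on an aromatic carbon). This change moves the number a number 19 percentage points lower from compound 1 to compound 3 (beyond the scatter) in this assay, a modest step but one that lies beyond the scatter of repeated measurements. Compound 2 stands lowest of the three numbers; its nearest neighbour is compound 3 and its furthest is compound 1, both gaps beyond the scatter. How the core of compound 2 differs from the core of compound 1 is not broken down here.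

Compound 4 `COc1cc(C(=O)/C=C/c2cc(-c3cc(OC)c(OC)c(OC)c3)n[nH]2)cc(OC)c1OC` is not yet measured. It differs from compound 2 in one place, (methoxy in place of hydrogen on an aromatic carbon). Within the data shown here, this is the same kind of change as the one from compound 1 to compound 3, but not the same: around the place of entry in compound 4 the methoxy is, in addition, meta to a methoxy group, which is not the case in compound 3.

For compound 4 in this assay a step of a number 4 percentage points lower from compound 2 to compound 4 (within the scatter) is expected, a smaller movement than the measured one from compound 1 to compound 3, because compound 2 already gives -88% and little room remains for the number to fall further. Compound 4 is therefore estimated at -92%, with a likely range from -100% to -76%.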

Compound 4, a percentage reported as activity, at one concentration (the size of the read-out at that concentration, not a potency): -77%
Compound 4: middle estimate off by 15 percentage points, on the low side; the measured number falls inside the stated range.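

In this assay the methoxy in place of hydrogen on an aromatic carbon gives a number 11 percentage points higher from compound 2 to compound 4 (beyond the scatter), so on this core the added group goes with a weaker effect at the concentration tested, although compound 4 still reads -77%. Among these compounds, only two pairs stand behind this comparison, and they differ in more than the core: in compound 4 the entering methoxy is also meta to a methoxy group, which is not the case in compound 3, so the data cannot separate the influence of the core from that of the surroundings at the place of entry. Within these limits, the change does not carry a fixed direction or size from one core to the other, and a step measured on one core is a poor guide to the step on the other: the same change on two cores in this assay, a number 19 percentage points lower (beyond the scatter) from compound 1 to compound 3 and a number 11 percentage points higher (beyond the scatter) from compound 2 to compound 4, 30 percentage points apart, beyond the scatter of two such steps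

Open, going by these compounds, is how a hydroxy group or a chlorine atom in the same place would compare with methoxy on either core. Also open, on these data alone, is whether the opposite directions of the two steps persist at lower concentrations or in other cell lines.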